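Swapping the Chloroacyl Arm for a Chlorobenzyl Arm

The source may hold more compounds than are shown below. What is called first, only, known or untested is meant among the compounds shown, and "the series" means these compounds.

Measured compounds and their values:
compound 1 `Cc1nnc(SCc2ccccc2Cl)n1N1C(=O)c2ccccc2C1=O`: > 200000 nM
compound 2 `CCc1nnc(SCC(=O)c2ccc(Cl)cc2)n1N1C(=O)c2ccccc2C1=O`: > 200000 nM
compound 3 `CCCc1nnc(SCC(=O)c2ccc(Cl)cc2)n1N1C(=O)c2ccccc2C1=O`: > 200000 nM

In a functional assay on MKN-45 cells (Homo sapiens) for cytotoxicity, read by MTT assay, with a stated time of 48 h (on this read-out lower numbers stand for stronger inhibition and higher numbers for weaker inhibition), compound 3 gives > 200000 nM, which is a limit of the assay and not a measured number. Compound 2 likewise gives > 200000 nM, again a limit. Compound 1 also stops at > 200000 nM, a limit as well. So far, then, every value shown is the limit of > 200000 nM in this assay, at which 3 of the 3 values shown sit, and none of the compounds has produced a readable number.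

Compound 4 `CCCc1nnc(SCc2ccccc2Cl)n1N1C(=O)c2ccccc2C1=O` is not yet measured. It differs from compound 3 by 2-chlorophenyl in place of (4-chlorophenyl)carbonyl on a saturated chain carbon bound to a sulfur. For the measured compounds named here, only one measured step exists, the step that the two limits leave unreadable from compound 2 to compound 3, and the two limits leave its size unreadable, so it says nothing about how a change on the chain bound to sulfur plays out. Compound 1, which carries the same 2-chlorobenzyl arm as compound 4, also sits at the limit, which gives no hint of a readable number for that arm either.

With every measured value at the limit, compound 4 is expected to remain at the limit too, an expected step of a number no higher from compound 3 to compound 4 (the limit leaves the size open); the estimate for compound 4 is 200000 nM, within a range from 60000 nM to 200000 nM.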

Compound 4, half-maximal inhibitory concentration: > 200000 nM
Compound 4: a limit, no number (the forecaster's own chance of this, stated with the estimate: 85%); the middle value lies on the limit itself.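

In this assay compound 4 gives > 200000 nM, which is a limit of the assay and not a number. The steps from compound 1 and from compound 3 to compound 4 therefore cannot be read: the limit of > 200000 nM in this assay, at which 4 of the 4 values shown sit. The compounds shown leave open whether the 2-chlorobenzyl and ((4-chlorophenyl)carbonyl)methyl arms differ at all in this assay.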